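The compounds below may be only part of what the source reports. "The series", "measured", "known", "first", "only" and "open" are said of these compounds alone.

Measured compounds:
Compound 1, `COc1ccc(OCCCON2C(N)=NC(N)=NC23CCOCC3)cc1`: in an assay on isolated protein for inhibition of Dihydrofolate reductase (Homo sapiens), read by spectrophotometry, using NADPH, with stated times of 5 s and 6 min, tested at 5 uM (on this read-out lower numbers stand for a weaker effect and higher numbers for a stronger effect at the one concentration tested), compound 1 gives > 90%, which is a limit of the assay and not a number.
Compound 2, `NC1=NC2(CCOCC2)N(OCCCOc2ccc(Cl)cc2)C(N)=N1`: compound 2 gives > 90%, again a limit.
Compound 3, `NC1=NC2(CCOCC2)N(OCCCOc2ccccc2Cl)C(N)=N1`: compound 3 gives 83.3%.

Going by the values given here, compound 3 therefore holds the only plain number in the set; the two other values sit at the limit of > 90% in this assay, at which 2 of the 3 values shown sit. The steps toward it read a number at least 6.7 percentage points lower from compound 1 to compound 3 (that floor lies within the scatter) and a number at least 6.7 percentage points lower from compound 2 to compound 3 (that floor lies within the scatter), each with a floor inside the scatter, while a step that the two limits leave unreadable from compound 1 to compound 2 cannot be read from the two limits.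

Compound 4, `NC1=NC2(CCOCC2)N(OCCCOc2ccc(F)cc2)C(N)=N1`, differs from compound 3 only in the aryl group: 4-fluorophenyl in place of 2-chlorophenyl on an oxygen on a saturated carbon. The 4-fluorophenyl that enters follows the pattern of 4-chlorophenyl in compound 2 and 4-methoxyphenyl in compound 1 rather than that of 2-chlorophenyl in compound 3. The nearest measured step, from compound 2 to compound 3, ran downward by at least its floor; the present change runs the other way, so an upward step of roughly that size, a number 6.7 percentage points higher from compound 3 to compound 4 (within the scatter), is expected, with the read-out likely returning to the limit. For compound 4 the estimated value is 90%, ranging from 82% to 96%.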

Compound 4, a percentage reported as inhibition, at one concentration (the size of the read-out at that concentration, not a potency): > 90%
Compound 4 was reported as a limit; the forecaster's own chance of this, stated with the estimate: 55%; the middle value lies on the limit itself.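

Working notes on the aryl group on the oxygen: in this assay, 4-fluorophenyl in place of 2-chlorophenyl gives a number at least 6.7 percentage points higher from compound 3 to compound 4 (that floor lies within the scatter), so this change is not shown to exceed the scatter. Going by these compounds alone, the 4-fluorophenyl group joins 4-chlorophenyl and 4-methoxyphenyl at the limit of the assay, and compound 3, with 2-chlorophenyl, is the one compound that goes against this pattern by giving a plain number. The steps among compound 1, compound 2 and compound 4 cannot be read, and at this one concentration the read-out does not separate these three groups: the limit of > 90% in this assay, at which 3 of the 4 values shown sit.

Still open, from the compounds shown here alone, is whether compound 3 truly differs from the other three compounds, and how the three groups at the limit rank among themselves. Also open, going by these compounds, is how an amine or a carboxylic acid on the phenyl ring, or a longer chain at this place, would read.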